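This account rests on a few compounds, and the source may have more. Where it says the series, first, only, none or still open, it means among the compounds named here.

Measured in a functional assay for inhibition, tested at 20 ug/mL; on this read-out lower numbers stand for a weaker effect and higher numbers for a stronger effect at the one concentration tested:

compound 1, `COc1cc(OC)c(-c2cc(-c3cc(C(C)C)c(O)cc3C)[nH]c(=O)c2C#N)c(OC)c1`: 32%
compound 2, `Cc1cc(O)c(C(C)C)cc1-c1cc(-c2ccco2)c(C#N)c(=O)[nH]1`: 26%

Of the compounds shown here, two have been measured so far in this assay. Compound 1, `COc1cc(OC)c(-c2cc(-c3cc(C(C)C)c(O)cc3C)[nH]c(=O)c2C#N)c(OC)c1`, gives 32% there, and compound 2, `Cc1cc(O)c(C(C)C)cc1-c1cc(-c2ccco2)c(C#N)c(=O)[nH]1`, gives 26%. Compound 2 has the smaller of the two numbers, but the gap to compound 1 is within the usual scatter of repeated measurements, so the two read-outs cannot be told apart, and neither compound can be called the stronger of the pair.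

Compound 3, `Cc1cc(O)c(C(C)C)cc1-c1cc(-c2ccccc2)c(C#N)c(=O)[nH]1`, has not yet been measured. Its structure differs from that of compound 2 in one place: phenyl in place of furan-2-yl on an aromatic carbon. Among the measured compounds shown here, no pair of measured compounds shows this kind of exchange, so nothing in the data indicates which way the read-out moves. The step of a number 2 percentage points higher from compound 2 to compound 3 (within the scatter) is therefore expected to stay within the scatter, with no direction that can be claimed. Because compound 2 gives 26% in this assay, compound 3 is expected to land near that figure. For compound 3 the estimate in this assay is 28%, with a range from 12% to 48%.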

Compound 3, a percentage reported as inhibition, at one concentration (the size of the read-out at that concentration, not a potency): 22%
Estimate against measurement, compound 3: 6 percentage points above, within the range that was stated.
By their numbers in this assay, from the lowest: compounds 3, 2 and 1 (each within the scatter of the next).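

In this assay, among the compounds shown here, the exchange of furan-2-yl for phenyl on the aromatic carbon ortho to a cyano group gives the first comparison in which only this position differs, and the read-out is a number 4 percentage points lower from compound 2 to compound 3 (within the scatter). A five-membered aromatic ring with a hetero atom and a hydrogen-bond acceptor thus gives way to a six-membered aromatic ring of carbon only, with no difference that can be told apart from repeat scatter, so at this single test concentration the two groups cannot be ranked. No measurement is available that bears on why the two read-outs lie so close together.

What this one exchange leaves open is whether any group at this position can shift the read-out beyond the scatter, since both groups compared here are aromatic rings without a hydrogen-bond donor. An amine, a carboxylic acid or a longer alkyl chain on the same aromatic carbon would test that question, and a single step between two aromatic rings says nothing about how such groups would behave.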